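The source may report more compounds than this note shows. Statements on the series, on what has been measured and on what is new or still open speak of the compounds shown alone.

Measured in a functional assay (aorta) for inhibition, with Rattus norvegicus as the target, with a stated time of 8 days; a lower number here means a stronger inhibitor, a higher number a weaker inhibitor:
- compound 1 `Cc1nsc(-c2ccc(N3CCN(c4cccc(Cl)c4)CC3)nn2)n1`: 0.6 nM
- compound 2 `Cc1nsc(-c2ccc(N3CCN(c4cccc(C(F)(F)F)c4)CC3)cc2)n1`: 10 nM
- compound 3 `Cc1nsc(-c2ccnc(N3CCN(c4cccc(C(F)(F)F)c4)CC3)n2)n1`: > 100 nM

Compound 1 stands lowest of the numbers, and the nearest number, from compound 2 at 10 nM, lies beyond the scatter. The entry for compound 3, > 100 nM, is a limit and not a number.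

Next is compound 4 `Cc1nsc(-c2ccc(N3CCN(c4cc(Cl)cc(Cl)c4)CC3)nn2)n1`, where the 3-chlorophenyl of compound 1 becomes 3,5-dichlorophenyl chloro in place of hydrogen on an aromatic carbon. Within the data shown here, no measured pair shows this change. Compound 1 at 0.6 nM already sits lowest, so a further fall is not assumed. The estimated 2.5-fold higher number from compound 1 to compound 4 (0.40 log units; beyond the scatter) is small, toward a higher number. For compound 4 the expected value is 1.5 nM, with an estimated range from 0.3 nM to 8 nM.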

Compound 4, half-maximal inhibitory concentration: < 0.1 nM
Compound 4: no number, only a limit (the forecaster's own chance of this, stated with the estimate: 3%); middle value at least 15-fold (1.17 log units) from the limit.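

In this assay, a chloro on an aromatic carbon, meta to a chloro group, gives an at least 6.0-fold lower number from compound 1 to compound 4 (0.77 log units; beyond the scatter). Among these compounds, this is the first single-change step, and it shows that the low number of compound 1 was not the end of the range at this position. For compound 4, the entry < 0.1 nM is a limit and not a number.

As far as these compounds go, whether a methoxy group, a nitrile or an amine on the same carbon would give a similar step remains open. So does whether the second chloro acts the same way on the cores of compound 2 and compound 3.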